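The compounds below may be only part of what the source reports. "The series", "measured", "known", "first", "only" and "open" are said of these compounds alone.

Measured compounds in an ADME assay on MT4 cells (Homo sapiens) for cytotoxicity, read by MTT assay, with a stated time of 4 days; on this read-out higher numbers stand for lower toxicity in this test and lower numbers for higher toxicity in this test:
- compound 1 `Cc1cc(-c2cccc(C#N)c2)cc(C)c1Nc1ccnc(Nc2ccc(C#N)cc2)n1` gives 920 nM
- compound 2 `Cc1ccccc1-c1cc(C)c(Nc2ccnc(Nc3ccc(C#N)cc3)n2)c(C)c1` gives 3820 nM
- compound 3 `Cc1cc(-c2ccccc2F)cc(C)c1Nc1ccnc(Nc2ccc(C#N)cc2)n1` gives 2120 nM

Among these three, compound 3 stands second highest. Its nearest neighbour is compound 2, and the step of a 1.8-fold lower number from compound 2 to compound 3 (0.26 log units; within the scatter) stays within the scatter, so the two cannot be ranked. Compound 1 is further away, with the step of a 2.3-fold higher number from compound 1 to compound 3 (0.36 log units; beyond the scatter) beyond the scatter.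

Compound 4 `Cc1ccc(-c2cc(C)c(Nc3ccnc(Nc4ccc(C#N)cc4)n3)c(C)c2)cc1` differs from compound 3 in one place: 4-methylphenyl in place of 2-fluorophenyl on an aromatic carbon. The measured steps that bear on this are those exchanging the group on the same aromatic carbon. The step of a 1.8-fold lower number from compound 2 to compound 3 (0.26 log units; within the scatter) shows that swapping fluoro for methyl on that ring changed little, while a 4.2-fold higher number from compound 1 to compound 2 (0.62 log units; beyond the scatter) and a 2.3-fold higher number from compound 1 to compound 3 (0.36 log units; beyond the scatter) show modest movement when a nitrile is removed. Since compound 4 carries a methyl on this ring much as compound 2 does, the expected step of a 1.4-fold higher number from compound 3 to compound 4 (0.15 log units; within the scatter) in this assay is small, likely within the scatter. Compound 4 is therefore estimated at 3000 nM, with a range from 1200 nM to 7500 nM.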

Compound 4, half-maximal cytotoxic concentration: 5570 nM
Compound 4: the middle estimate sits 1.9-fold (0.27 log units) below what was measured; the measured number falls inside the stated range.
By their numbers in this assay, from the lowest: compound 1; then compounds 3, 2 and 4 (each within the scatter of the next, the first and the last beyond it).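

In this assay, going by these compounds alone, the exchange of 2-fluorophenyl for 4-methylphenyl (a 2.6-fold higher number from compound 3 to compound 4 (0.42 log units; beyond the scatter)) is the first step among the groups lacking a nitrile that lies beyond the scatter, so this position can separate such groups. That separation has limits, since the exchange of 2-methylphenyl for 4-methylphenyl (a 1.5-fold higher number from compound 2 to compound 4 (0.16 log units; within the scatter)) stays within the scatter and the two cannot be ranked. The largest step shown is the exchange of 3-cyanophenyl for 4-methylphenyl (a 6.1-fold higher number from compound 1 to compound 4 (0.78 log units; beyond the scatter)), and 3-cyanophenyl still gives the lowest number of the set, with no compound here going against that.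

Nothing shown explains these steps. Going by these compounds, it also remains open how this assay would respond to an amine or a carboxylic acid on this aromatic ring, or to a simple methyl in place of the whole ring.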